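Chloro for trifluoromethyl on the thiourea aryl ring

This account rests on a few compounds, and the source may have more. Where it says the series, first, only, none or still open, it means among the compounds named here.

Two thioureas of the shared core have been measured in a functional assay on HepG2 cells (Homo sapiens) for antiproliferative activity, read by MTT assay; a lower number here means a stronger inhibitor, a higher number a weaker inhibitor. Compound 1 `CNC(=O)c1ccc(Oc2cccc(NC(=S)Nc3cc(C(F)(F)F)cc(C(F)(F)F)c3)c2)nc1` gives 4550 nM. Compound 2 `CNC(=O)c1ccc(Oc2cccc(NC(=S)Nc3ccc(F)c(C(F)(F)F)c3)c2)nc1` gives 20200 nM, the higher of the two numbers, and the gap to compound 1 lies beyond the scatter. Compound 3 `CNC(=O)c1ccc(Oc2cccc(NC(=S)Nc3ccc(F)c(Cl)c3)c2)nc1` is not yet measured; it differs from compound 2 by chloro in place of trifluoromethyl on an aromatic carbon. Among the compounds with values here, no step of this kind exists among the measured pairs, so the direction is uncertain. The step from compound 2 to compound 3 is expected to be small, a 1.1-fold lower number from compound 2 to compound 3 (0.05 log units; within the scatter), within or only slightly beyond the scatter. For compound 3 the estimate in this assay is 18000 nM, with a range from 6000 nM to 55000 nM.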

Compound 3, half-maximal inhibitory concentration: > 100000 nM
Compound 3: a limit, no number (the forecaster's own chance of this, stated with the estimate: 15%); at least 5.5-fold (0.74 log units) between middle value and limit.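

On the aromatic carbon ortho to a fluoro group, chloro in place of trifluoromethyl is not a silent swap in this assay: the change gives an at least 4.9-fold higher number from compound 2 to compound 3 (0.69 log units; beyond the scatter). Trifluoromethyl at this place goes with a measured number, whereas chloro does not reach one. For compound 3 the read-out is a limit and not a number, so the step has a lower bound only: the limit of > 100000 nM in this assay, at which 1 of the 3 values shown sits.

As far as these compounds go, whether methyl or bromo at this place would return a number in this assay stays open. Also open, from the compounds shown here alone, is how far compound 3 lies past its limit.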